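The source may hold more compounds than are shown below. What is called first, only, known or untested is meant among the compounds shown, and "the series" means these compounds.

Working notes on the series. Compound 1 `C=CCC1COC2(C=CC(=O)C=C2)N(C(C)C)C1=O`, compound 2 `CC(C)N1C(=O)C(Cc2ccc(F)cc2)COC12C=CC(=O)C=C2` and compound 3 `CC(C)N1C(=O)C(Cc2ccc(C(F)(F)F)cc2)COC12C=CC(=O)C=C2` have been run in an assay on isolated protein for inhibition of N-lysine methyltransferase SMYD2 (Homo sapiens), read by filter binding, with a stated time of 1 h; on this read-out higher numbers stand for weaker inhibition and lower numbers for stronger inhibition. Compound 1 reaches only the limit of > 20000 nM, not a measured number. Compound 2 likewise stops at the limit > 20000 nM. Compound 3 also gives only the limit > 20000 nM. Compound 3 therefore stands exactly where every tested member stands, at the limit, with no number to set it against the others, as the limit of > 20000 nM in this assay, at which 3 of the 3 values shown sit, records. The step that the two limits leave unreadable from compound 1 to compound 2 is left unreadable by the two limits, and the step that the two limits leave unreadable from compound 2 to compound 3 is unreadable for the same reason. Compound 4 `CC(C)N1C(=O)C(Cc2ccc([N+](=O)[O-])cc2)COC12C=CC(=O)C=C2` is not yet tested; its change from compound 3 is nitro in place of trifluoromethyl on an aromatic carbon. The step from compound 2 to compound 3 alters the same aromatic substituent that changes here, while the step from compound 1 to compound 2 alters the group on the chain; neither yields a size, so no step beyond the scatter can be read off. The step that the limit leaves unreadable from compound 3 to compound 4 is therefore expected to be small, most likely ending at the limit once more. Compound 4 is expected to give 30000 nM in this assay, between 10000 nM and 100000 nM.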

Compound 4, half-maximal inhibitory concentration: > 20000 nM
Compound 4: only a limit was reported (the forecaster's own chance of this, stated with the estimate: 85%); the middle value lies beyond the limit too.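

Compound 4 adds no readable step against compound 3 or compound 2 in this assay, and the series stands at: the limit of > 20000 nM in this assay, at which 4 of the 4 values shown sit.

The compounds shown leave open how large any of these steps is, and whether any change to the shared core gives a number rather than a limit.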